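Changing the acyl side chain on a piperazine amide

The source may report more compounds than this note shows. Statements on the series, on what has been measured and on what is new or still open speak of the compounds shown alone.

Measured compounds:
- compound 1, `COc1ccc(CC(C)C(=O)N2CCN(c3ccc(C(F)(F)F)cc3[C@@H](N)CC(C)C)CC2)cc1`: 120 nM
- compound 2, `Cc1cc(CC(C)C(=O)N2CCN(c3ccc(C(F)(F)F)cc3[C@@H](N)CC(C)C)CC2)ccc1Cl`: 71 nM
- compound 3, `CC(C)C[C@H](N)c1ccccc1N1CCN(C(=O)[C@H](C)Cc2ccc(Cl)cc2Cl)CC1`: 16 nM

In an assay on HEK293 cells for displacement of a labelled ligand from Melanocortin receptor 4 (Homo sapiens) (on this read-out higher numbers stand for weaker inhibition and lower numbers for stronger inhibition), compound 2 gives 71 nM, the second highest of the three numbers. Its nearest neighbour is compound 1, from which it differs only in the aryl group on the side chain; that step, a 1.7-fold lower number from compound 1 to compound 2 (0.23 log units; within the scatter), is within the scatter. For the measured compounds named here, compound 3, which has a different core, gives 16 nM, a lower number than compound 2, but no single-change step links the two.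

Compound 4, `Cc1ccc(OCC(=O)N2CCN(c3ccc(C(F)(F)F)cc3[C@@H](N)CC(C)C)CC2)cc1`, is not yet measured. It differs from compound 2 in (4-methylphenoxy)methyl in place of 1-(4-chloro-3-methylbenzyl)ethyl on a carbonyl carbon. Going by the values given here, this change is larger than the one between compound 1 and compound 2: the branch on the chain is removed, an oxygen enters the chain, and the chlorine on the ring is lost. Among the compounds with values here, the only directly comparable step, a 1.7-fold lower number from compound 1 to compound 2 (0.23 log units; within the scatter), shows that swapping the aryl substituents alone made little difference, but nothing measured here covers a change to the chain itself.

Compound 4 is therefore estimated at 200 nM, with a range from 60 nM to 700 nM, which would mean an expected step of a 2.8-fold higher number from compound 2 to compound 4 (0.45 log units; beyond the scatter), modestly toward a higher number.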

Compound 4, inhibition constant: 4400 nM
The estimate for compound 4 lay 22-fold (1.34 log units) below the measured number, and the stated range ends below it.
By their numbers in this assay, from the lowest: compound 3; then compounds 2 and 1 (each within the scatter of the next); then compound 4.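

In this assay, the group on the carbonyl carbon proves far more sensitive to a change in the chain than to a change of ring substituents: the step of a 1.7-fold lower number from compound 1 to compound 2 (0.23 log units; within the scatter) stayed within the scatter, yet (4-methylphenoxy)methyl brings a 62-fold higher number from compound 2 to compound 4 (1.79 log units; beyond the scatter) and also a 37-fold higher number from compound 1 to compound 4 (1.56 log units; beyond the scatter). Both large steps point the same way, toward weaker inhibition, whichever of the two branched groups is replaced, so with the shared core held constant, the loss does not depend on which of those two rings was present. No measurement available here explains this loss.

The swap alters several things at once, since the branch goes, an oxygen enters the chain and the ring substituents differ, so the compounds shown cannot assign the loss to any one of these features. Going by these compounds, it remains open whether an all-carbon chain without the branch, or a branched chain that keeps the oxygen, would sit closer to compound 2 or to compound 4, and whether an amine nitrogen in place of that oxygen would behave differently.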